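A few compounds are considered here, and "the series" means these few. Any claim that something is new, unique, unknown or untested is made for them only; others in the source may bear on it.

Compound 1 `O=C1C2CCCN2C(=O)N1CCCN1CCN(c2ccccc2)CC1` gives the lowest number of the two measured in an assay on isolated protein for binding affinity to Adrenergic receptor alpha-1 (Rattus norvegicus), read by radioligand binding (a higher number here means a weaker inhibitor, a lower number a stronger inhibitor), namely 15.4 nM. Among the compounds with values here, compound 2 `O=C1C2CCCN2C(=O)N1CCCN1CCN(c2cccc(C(F)(F)F)c2)CC1` gives 109 nM; the only measured step, a 7.1-fold higher number from compound 1 to compound 2 (0.85 log units; beyond the scatter), comes from a trifluoromethyl in place of hydrogen on an aromatic carbon. Compound 3 `O=C1C2CCCN2C(=O)N1CCCN1CCN(c2ccc([N+](=O)[O-])cc2)CC1` is not yet measured; it differs from compound 1 by nitro in place of hydrogen on an aromatic carbon. Within the data shown here, the one measured step bears only loosely on this change, yet it points toward a weaker binder when a group enters that ring, so a modest rise is expected, a 3.2-fold higher number from compound 1 to compound 3 (0.51 log units; beyond the scatter). Compound 3 is therefore estimated at 50 nM, ranging from 15 nM to 170 nM.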

Compound 3, inhibition constant: > 1000 nM
Compound 3 gave a limit, no number; the forecaster's own chance of this, stated with the estimate: 2%; middle value at least 20-fold (1.30 log units) away from the limit.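

Swapping phenyl for 4-nitrophenyl, which places nitro on the aromatic ring para to a large group, gives an at least 64-fold higher number from compound 1 to compound 3 (1.81 log units; beyond the scatter) in this assay. This shows that one small group at this position can weaken binding greatly, so an unsubstituted ring is clearly preferred to this nitro ring. The true size of the step stays unknown, as compound 3 gave a limit and not a number: the limit of > 1000 nM in this assay, at which 1 of the 3 values shown sits.

Still open, on these data alone, is whether an amine or a methoxy group at this position would cost as much. As far as these compounds go, it is also open whether nitro elsewhere on the ring would do the same.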